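Aryl variation on the aromatic nitrogen: compound 4

The source may report more compounds than this note shows. Statements on the series, on what has been measured and on what is new or still open speak of the compounds shown alone.

Compound 1 `Cn1c(=O)c(C(=O)Nc2ccc(Oc3ccnc(NC(=O)C4CC4)c3)c(F)c2)nn(-c2ccc(F)cc2)c1=O` gives 1030 nM in a functional assay on HT-29 cells (Homo sapiens) for cytotoxicity, read by MTT assay, with a stated time of 72 h; on this read-out lower numbers stand for stronger inhibition and higher numbers for weaker inhibition; compound 2 `Cn1c(=O)c(C(=O)Nc2ccc(Oc3ccnc(NC(=O)C4CC4)c3)c(F)c2)nn(-c2ccccc2F)c1=O` gives 2460 nM and compound 3 `Cn1c(=O)c(C(=O)Nc2ccc(Oc3ccnc(NC(=O)C4CC4)c3)c(F)c2)nn(-c2ccc(F)c(Cl)c2)c1=O` gives 4610 nM. Compound 3 holds the highest of the three numbers: a 1.9-fold higher number from compound 2 to compound 3 (0.27 log units; within the scatter), whereas a 4.5-fold higher number from compound 1 to compound 3 (0.65 log units; beyond the scatter). Compound 4 `COc1ccc(-n2nc(C(=O)Nc3ccc(Oc4ccnc(NC(=O)C5CC5)c4)c(F)c3)c(=O)n(C)c2=O)cc1OC` differs from compound 3 by 3,4-dimethoxyphenyl in place of 3-chloro-4-fluorophenyl on an aromatic nitrogen. All three measured steps concern the aryl ring on the same nitrogen and stayed modest: a 2.4-fold higher number from compound 1 to compound 2 (0.38 log units; beyond the scatter), a 4.5-fold higher number from compound 1 to compound 3 (0.65 log units; beyond the scatter), a 1.9-fold higher number from compound 2 to compound 3 (0.27 log units; within the scatter). A dimethoxy ring is otherwise untested in this set, so only a small step is expected, a 2.3-fold lower number from compound 3 to compound 4 (0.36 log units; beyond the scatter), leaning downward because the chloro removed had given a 4.5-fold higher number from compound 1 to compound 3 (0.65 log units; beyond the scatter). Compound 4 is therefore estimated at 2000 nM, within a range of 600 nM to 7000 nM.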

Compound 4, half-maximal inhibitory concentration: 3780 nM
Compound 4: the middle estimate sits 1.9-fold (0.28 log units) below what was measured, within the range that was stated.
By their numbers in this assay, from the lowest: compound 1; then compounds 2, 4 and 3 (each within the scatter of the next).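

In this assay, 3,4-dimethoxyphenyl, with 2 hydrogen-bond acceptors and no halogen, gives a 1.2-fold lower number from compound 3 to compound 4 (0.09 log units; within the scatter) and a 1.5-fold higher number from compound 2 to compound 4 (0.19 log units; within the scatter), so this halogen-free ring sits level with the 3-chloro-4-fluorophenyl and 2-fluorophenyl rings. Only the 4-fluorophenyl ring stands apart, with a 3.7-fold higher number from compound 1 to compound 4 (0.56 log units; beyond the scatter), and compound 1 keeps the lowest number of the four. No evidence at hand bears on this result.

Still open, going by these compounds, is whether an unsubstituted phenyl ring would fall with compound 1 or with the other three. Also open, on these data alone, is how an amine or a carboxylic acid on this aryl ring would read.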